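Series notes: methoxy to chloro on the pendant aryl ring

A few compounds are considered here, and "the series" means these few. Any claim that something is new, unique, unknown or untested is made for them only; others in the source may bear on it.

Measured compounds:
compound 1, `COc1cc(/C=C/C(=O)c2cccc(-n3cc(-c4ccc(Cl)cc4)[nH]c3=O)c2)cc(OC)c1OC`, 3630 nM
compound 2, `COc1ccc(-c2cn(-c3cccc(C(=O)/C=C/c4ccc(O)c(OC)c4)c3)c(=O)[nH]2)cc1`, 3350 nM
compound 3, `COc1ccc(-c2cn(-c3cccc(C(=O)/C=C/c4cc(OC)c(OC)c(OC)c4)c3)c(=O)[nH]2)cc1`, 1860 nM

All three were run in a functional assay on MDA-MB-435 cells (Homo sapiens) for inhibition; on this read-out lower numbers stand for stronger inhibition of growth and higher numbers for weaker inhibition of growth. Compound 3 gives 1860 nM, and compound 2 gives 3350 nM; the two differ in the aryl group on the chain, and that difference is 4-hydroxy-3-methoxyphenyl in place of 3,4,5-trimethoxyphenyl on a double-bonded chain carbon bound to a double-bonded chain carbon. The step is a 1.8-fold lower number from compound 2 to compound 3 (0.26 log units; within the scatter), so the two cores cannot be told apart on this read-out.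

Compound 1 gives 3630 nM in this assay. It differs from compound 3 by chloro in place of methoxy on an aromatic carbon, and the step is a 2.0-fold higher number from compound 3 to compound 1 (0.29 log units; within the scatter).

Compound 4, `COc1cc(/C=C/C(=O)c2cccc(-n3cc(-c4ccc(Cl)cc4)[nH]c3=O)c2)ccc1O`, has not yet been measured in this assay. It differs from compound 2 by chloro in place of methoxy on an aromatic carbon. Within the data shown here, this is the same change as the one made from compound 3 to compound 1: the leaving group, the entering group and the place are the same word for word. Among the measured compounds shown here, the only prior instance of this change, the step of a 2.0-fold higher number from compound 3 to compound 1 (0.29 log units; within the scatter), lies within the scatter, so the expectation for compound 4 rests on a single step that may itself be noise. For compound 4 the step from compound 2 is expected to be about a 1.8-fold higher number from compound 2 to compound 4 (0.25 log units; within the scatter). Compound 4 is therefore estimated at 6000 nM in this assay, with a range from 2500 nM to 15000 nM expected to cover most repeats.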

Compound 4, concentration for 50% growth inhibition: 2250 nM
For compound 4 the middle estimate is 2.7-fold (0.43 log units) above the measured one; measured number outside the range, below it.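

The new step is a 1.5-fold lower number from compound 2 to compound 4 (0.17 log units; within the scatter), so taken alone the change from 4-methoxyphenyl to 4-chlorophenyl does not separate these two compounds in this assay. Set beside the earlier step, the change does not carry over from one core to the other as a single fixed shift: the same change on two cores in this assay, a 2.0-fold higher number (0.29 log units; within the scatter) from compound 3 to compound 1 and a 1.5-fold lower number (0.17 log units; within the scatter) from compound 2 to compound 4, 2.9-fold (0.46 log units) apart, beyond the scatter of two such steps

This shows that a step read on one of these cores is a poor guide to the same change on the other, but each step remains small when taken alone. It does not show that either step is a real shift in growth inhibition, or that the core sets the size or direction of the change, since there is only one matched pair on each core and no repeats are shown.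

The compounds shown leave open how this place on the aromatic ring responds to other groups, such as an amine or a carboxylic acid in place of the chloro or methoxy group. They also leave open whether the same change from methoxy to chloro would track either step on a core with a different aryl group on the chain, such as 4-aminophenyl.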